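The compounds below may be only part of what the source reports. "The series", "measured", "known", "first", "only" and "open" are said of these compounds alone.

Measured so far, in a functional assay on 1321-N1 cells for agonist activity at P2Y purinoceptor 2 (Homo sapiens), read by scintillation counting and inositol phosphate accumulation; a lower number here means that less compound is needed, a higher number that more compound is needed for the effect:
Compound 1, `O=C(O)CCCO/N=c1/ccn([C@@H]2O[C@H](COP(=O)(O)OP(=O)(O)OP(=O)(O)O)[C@@H](O)[C@H]2O)c(=O)[nH]1`, gives 299 nM.
Compound 2, `O=c1[nH]/c(=N\OCCCc2cccc(F)c2)ccn1[C@@H]1O[C@H](COP(=O)(O)OP(=O)(O)OP(=O)(O)O)[C@@H](O)[C@H]1O`, gives 190 nM.
Compound 3, `O=c1[nH]/c(=N\OCCCc2cccc([N+](=O)[O-])c2)ccn1[C@@H]1O[C@H](COP(=O)(O)OP(=O)(O)OP(=O)(O)O)[C@@H](O)[C@H]1O`, gives 457 nM.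

Compound 3 has the highest number of the three; its gap to compound 1 is within the scatter, while the step of a 2.4-fold higher number from compound 2 to compound 3 (0.38 log units; beyond the scatter) goes beyond it. Compound 4, `COc1ccc(CCCO/N=c2/ccn([C@@H]3O[C@H](COP(=O)(O)OP(=O)(O)OP(=O)(O)O)[C@@H](O)[C@H]3O)c(=O)[nH]2)cc1`, carries the change (4-methoxyphenyl in place of 3-nitrophenyl on a saturated chain carbon, three bonds along the chain from an oxygen); cut one bond further out, the same difference reads 3-nitrobenzyl to 4-methoxybenzyl. Among the measured compounds shown here, three steps bear on it: a 1.6-fold lower number from compound 1 to compound 2 (0.20 log units; within the scatter), a 1.5-fold higher number from compound 1 to compound 3 (0.18 log units; within the scatter) and a 2.4-fold higher number from compound 2 to compound 3 (0.38 log units; beyond the scatter), all of them modest or within the scatter, so exchanging the group at this position has moved the number little. A small step down is therefore expected for compound 4, a 1.6-fold lower number from compound 3 to compound 4 (0.21 log units; within the scatter). The estimate for compound 4 in this assay is 280 nM, with a range from 120 nM to 650 nM.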

Compound 4, half-maximal effective concentration: 47 nM
For compound 4 the middle estimate is 6.0-fold (0.78 log units) above the measured one, and the stated range ends above it.
By their numbers in this assay, from the lowest: compound 4; then compounds 2, 1 and 3 (each within the scatter of the next, the first and the last beyond it).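

In this assay, the steps of a 9.7-fold lower number from compound 3 to compound 4 (0.99 log units; beyond the scatter) and a 4.0-fold lower number from compound 2 to compound 4 (0.61 log units; beyond the scatter) and a 6.4-fold lower number from compound 1 to compound 4 (0.80 log units; beyond the scatter) all lie beyond the scatter, so compound 4 has the lowest number of the four. The group on this saturated chain carbon can therefore shift the number more clearly than the earlier exchanges suggested, and 4-methoxyphenyl is the one that does so here. No measurement offered here explains this gain.

As far as these compounds go, compound 4 differs from the others in both the group and its printed ring position, so which of these matters remains open. A 3-methoxyphenyl or a 4-nitrophenyl group would help separate the two.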